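A few compounds are considered here, and "the series" means these few. Any claim that something is new, unique, unknown or untested is made for them only; others in the source may bear on it.

Compound 2 `CN(C)S(=O)(=O)NC[C@H]1CN(c2ccc(-n3cc(-c4ccccn4)cn3)c(F)c2)C(=O)O1` is the closest measured analogue of the unmeasured compound 3 `CCNC(=O)NC[C@H]1CN(c2ccc(-n3cc(-c4ccccn4)cn3)c(F)c2)C(=O)O1`. In a physicochemical assay for lipophilicity, read by HPLC, measured as octanol-water partition (on this read-out lower numbers stand for lower lipophilicity and higher numbers for higher lipophilicity), compound 2 gives 1.38. Compound 1 `CS(=O)(=O)NC[C@H]1CN(c2ccc(-n3cc(-c4ccccn4)cn3)c(F)c2)C(=O)O1`, which in this assay gives 1.38, stands at the same reading, and the step of no change at the digits printed from compound 1 to compound 2 (within the scatter) shows that exchanging methyl for dimethylamino on the sulfonyl sulfur left the value unchanged within the scatter. Within the data shown here, compound 2 therefore stands level with compound 1, with no measured compound above or below it beyond the scatter.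

Compound 3 differs from compound 2 by ethylcarbamoyl in place of dimethylsulfamoyl on an amine nitrogen; cut one bond further out this reads (dimethylsulfamoyl)amino to (ethylcarbamoyl)amino. Among the measured compounds shown here, no measured step covers this exchange: the only step known, from compound 1 to compound 2, concerns a change on the sulfonyl sulfur, and neither the group that leaves nor the group that enters in the present swap carries that sulfur. The shared core and its fluorine-bearing ring are untouched, so any shift should be modest.

For compound 3 the expected step is a number 0.18 log units lower from compound 2 to compound 3 (within the scatter), and the estimate in this assay is 1.2, within 0.7 to 1.7.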

Compound 3, partition coefficient: 2.45
Estimate against measurement, compound 3: 1.25 log units below; the whole stated range lies below it.
By their numbers in this assay, from the lowest: compounds 1 and 2 (each within the scatter of the next); then compound 3.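

In this assay, ethylcarbamoyl in place of dimethylsulfamoyl on the amine nitrogen gives a number 1.07 log units higher from compound 2 to compound 3 (beyond the scatter), and ethylcarbamoyl in place of methylsulfonyl at the same place gives a number 1.07 log units higher from compound 1 to compound 3 (beyond the scatter). The change on the sulfonyl sulfur between compound 1 and compound 2 left the reading level, whereas these steps, which replace the whole group on the nitrogen, show that this position can move the reading well beyond the scatter. Nothing shown gives a reason for the size of these steps.

Both steps replace the sulfonyl-bearing group and bring in the ethyl chain at once, so the compounds shown leave open whether the carbamoyl unit or the ethyl chain accounts for the shift in this assay; methylcarbamoyl, a longer chain on the carbamoyl nitrogen, or a plain acetyl group at this nitrogen would separate the two. Also open, from the compounds shown here alone, is whether a sulfonyl group carrying an ethylamino group would stay level with compound 2 or move towards compound 3.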